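This account rests on a few compounds, and the source may have more. Where it says the series, first, only, none or still open, it means among the compounds named here.

Measured compounds:
- compound 1 `CCCS(=O)(=O)c1ccc(F)c(C#Cc2cc(Cl)ccc2OCC(=O)O)c1`, in a functional assay on cells for antagonist activity at prostaglandin D2 receptor 2 (Homo sapiens), read by flow cytometry, with a stated time of 10 min (a lower number here means a stronger inhibitor, a higher number a weaker inhibitor), compound 1 gives 23 nM
- compound 2 `COCCNS(=O)(=O)c1ccc(C)c(C#Cc2cc(Cl)ccc2OCC(=O)O)c1`, in this assay compound 2 gives 88 nM

Among the compounds with values here, compound 2 stands at the higher of the two numbers in this assay; the gap to compound 1 is beyond the scatter, and no single-point step connects the two, as they differ in more than one place.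

Compound 3 `Cc1ccc(S(=O)(=O)N(C)C)cc1C#Cc1cc(Cl)ccc1OCC(=O)O` is not yet measured. It differs from compound 2 by one change: dimethylamino in place of (2-methoxyethyl)amino on a sulfonyl sulfur. Within the data shown here, no measured pair isolates this change, so there is no step to lean on. The change is small and confined to the sulfonamide substituent; compound 1, which carries a different sulfonyl substituent altogether, shows that variation at this position is tolerated within the range seen. Compound 3 is therefore expected near compound 2, with the step of a 1.3-fold lower number from compound 2 to compound 3 (0.10 log units; within the scatter) estimated as not beyond the scatter in either direction. The estimate for compound 3 in this assay is 70 nM, with a range from 25 nM to 200 nM.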

Compound 3, half-maximal inhibitory concentration: 77 nM
The estimate for compound 3 lay 1.1-fold (0.04 log units) below the measured number; measured number inside the range.
By their numbers in this assay, from the lowest: compound 1; then compounds 3 and 2 (each within the scatter of the next).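

Within the data shown here, the pair compound 2 and compound 3 gives the first single-point reading at this position: in this assay, dimethylamino in place of (2-methoxyethyl)amino on a sulfonyl sulfur gives a 1.1-fold lower number from compound 2 to compound 3 (0.06 log units; within the scatter). In this one pair, the number stays within the scatter even though the substituent goes from 5 heavy atoms to 3 and loses its hydrogen-bond donor and acceptor, so neither the methoxyethyl chain nor the nitrogen hydrogen is needed to hold the number here. Nothing measured on these compounds explains why the two substituents read alike.

Compound 1, at 23 nM, differs from the other two in more than one place, so its number cannot be assigned to any single change. Open too, from the compounds shown here alone, is how a longer chain, a terminal amine or a carboxylic acid on the sulfonamide nitrogen would read.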